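Trading 3-chlorophenyl for 1H-benzimidazol-2-yl

The compounds below may be only part of what the source reports. "The series", "measured", "known", "first", "only" and "open" are said of these compounds alone.

In a functional assay on MCF7 cells (Homo sapiens) for cytotoxicity, read by sulforhodamine B assay, with a stated time of 48 h (on this read-out lower numbers stand for stronger inhibition and higher numbers for weaker inhibition), compound 1 `N#Cc1cc(-c2ccccc2)n(-c2nc3ccccc3[nH]2)c1N` gives 1280 nM while compound 2 `Nc1c(-c2nc3ccccc3[nH]2)cc(-c2ccccc2)n1-c1ccccn1` gives 934 nM and compound 3 `Nc1c(-c2nc3ccccc3[nH]2)cc(-c2ccccc2)n1-c1cccc(Cl)c1` gives 1700 nM and so stands within the usual scatter of the other two. Compound 4 `Nc1c(-c2nc3ccccc3[nH]2)cc(-c2ccccc2)n1-c1nc2ccccc2[nH]1` differs from compound 3 by 1H-benzimidazol-2-yl in place of 3-chlorophenyl on an aromatic nitrogen and nowhere else. Going by the values given here, the one measured swap on that nitrogen gave a 1.8-fold higher number from compound 2 to compound 3 (0.26 log units; within the scatter) and so stayed small. Compound 1 already carries 1H-benzimidazol-2-yl on that nitrogen and gives 1280 nM within the same scatter. No step beyond the scatter is therefore expected in this assay for this change. The estimate implies a 1.4-fold lower number from compound 3 to compound 4 (0.15 log units; within the scatter) as the expected step. For compound 4 the expected value is 1200 nM with a range from 450 nM to 3200 nM as estimated.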

Compound 4, half-maximal inhibitory concentration: 1620 nM
Beside the measured number, compound 4's estimate is 1.4-fold (0.13 log units) below it, and the stated range covers the measured number.
By their numbers in this assay, from the lowest: compounds 2, 1, 4 and 3 (each within the scatter of the next).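

The bulkier, two-ring 1H-benzimidazol-2-yl, which brings a hydrogen-bond donor and acceptor that 3-chlorophenyl lacks, gives no step beyond the scatter on this aromatic nitrogen (a 1.0-fold lower number from compound 3 to compound 4 (0.02 log units; within the scatter)). The same holds against pyridin-2-yl (a 1.7-fold higher number from compound 2 to compound 4 (0.24 log units; within the scatter)). A change at a second place, 1H-benzimidazol-2-yl in place of cyano on an aromatic carbon, also stays within the scatter (a 1.3-fold higher number from compound 1 to compound 4 (0.10 log units; within the scatter)).

From the compounds shown here alone, whether a simple amine or a carboxylic acid on that nitrogen would give a larger step remains open. Nothing available explains why these exchanges show so little difference.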